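The compounds below may be only part of what the source reports. "The series", "measured", "known", "first", "only" and "open" are said of these compounds alone.

Compound 3 `CC(=O)N[C@@H]1CCCc2c1cncc2N1Cc2cc(Cl)ccc2C1=O` carries an acetamido group on the saturated ring of the shared core. In an ADME assay on microsomes from liver (Homo sapiens) for metabolic stability, read by LC-MS, using NADPH, with stated times of 10 min and 30 min (a lower number here means slower removal, a higher number faster removal of the compound), compound 3 gives < 3.5 mL/min/kg, which is a limit of the assay and not a number. Compound 1 `CC[C@@H]1c2cc(Cl)ccc2C(=O)N1c1cncc2c1CCC[C@H]2NC(C)=O` differs from it by an ethyl group on a saturated ring carbon. In this assay compound 1 gives < 3.5 mL/min/kg, again a limit. Compound 2 `CC(=O)N[C@@H]1CCCc2c1cncc2N1C(=O)c2ccc(Cl)cc2[C@@H]1C` carries a methyl group on the same kind of carbon instead. In this assay compound 2 gives < 3.5 mL/min/kg, also a limit. Because of the limit of < 3.5 mL/min/kg in this assay, at which 3 of the 3 values shown sit, both neighbouring steps, a step that the two limits leave unreadable from compound 1 to compound 3 and a step that the two limits leave unreadable from compound 2 to compound 3, cannot be read in size. Compound 4 `CS(=O)(=O)N[C@@H]1CCCc2c1cncc2N1Cc2cc(Cl)ccc2C1=O` is the unmeasured member: the change from compound 3 is methylsulfonyl in place of acetyl on an amine nitrogen. Going by the values given here, no measured step touches this amide-to-sulfonamide exchange, and the three known values only say where the floor lies. The expectation is therefore that compound 4 stays near that floor, with an estimated step that the limit leaves unreadable from compound 3 to compound 4. Compound 4 is accordingly estimated at 3 mL/min/kg, in a range from 1.5 mL/min/kg to 6.5 mL/min/kg.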

Compound 4, clearance: < 3.5 mL/min/kg
Compound 4 was reported as a limit; the forecaster's own chance of this, stated with the estimate: 65%; the middle value is on the limit's open side.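

In this assay no step can be read between compound 3 and compound 4, whose results are both limits of the assay and not numbers: the limit of < 3.5 mL/min/kg in this assay, at which 4 of the 4 values shown sit. The compounds shown leave open how the four compounds truly compare in this assay, and which change would give a value off that limit.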